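The source may hold more compounds than are shown below. What is called first, only, known or untested is meant among the compounds shown, and "the series" means these compounds.

Measured compounds in a functional assay, read by spectrophotometry, with a stated time of 15 min, tested at 60 ug/mL; on this read-out lower numbers stand for a weaker effect and higher numbers for a stronger effect at the one concentration tested:
- compound 1 `Clc1ccc(-c2csc(N/N=C/c3cccs3)n2)cc1`: 96.1%
- compound 2 `Cc1ccc(-c2csc(N/N=C/c3ccc(Cl)cc3Cl)n2)cc1`: 93.3%
- compound 3 `Cc1ccc(-c2csc(N/N=C/c3cccs3)n2)cc1`: 97.6%

On these three numbers compound 2 stands lowest, yet its gaps to compound 1 and to compound 3 both lie within the usual scatter of this assay, so the three compounds cannot be told apart on this read-out.

Compound 4 `Clc1ccc(-c2csc(N/N=C/c3ccc(Cl)cc3Cl)n2)cc1` has not yet been measured. It differs from compound 2 in one place: chloro in place of methyl on an aromatic carbon.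

Among the compounds with values here, one measured step bears directly on this change, in the opposite direction: a number 1.5 percentage points higher from compound 1 to compound 3 (within the scatter). That exchange moved the read-out by an amount inside the scatter. Because the step of a number 1.5 percentage points higher from compound 1 to compound 3 (within the scatter) was so small, the reverse exchange from compound 2 to compound 4 is expected to leave the read-out where it is, with no step beyond the scatter in either direction.

Compound 4 is therefore estimated at 93.5% in this assay, within a range of 86% to 98.5%, which means an expected step of a number 0.2 percentage points higher from compound 2 to compound 4 (within the scatter).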

Compound 4, a percentage reported as inhibition, at one concentration (the size of the read-out at that concentration, not a potency): 88.9%
Beside the measured number, compound 4's estimate is 4.6 percentage points above it; low and high end bracket the measured number.
By their numbers in this assay, from the lowest: compounds 4, 2, 1 and 3 (each within the scatter of the next).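

In this assay, chloro in place of methyl on an aromatic carbon, para to a large group, gives a number 4.4 percentage points lower from compound 2 to compound 4 (within the scatter). Within the data shown here, until now this exchange could be read on only one core, so a small step might have been peculiar to that core; on a second core it again stays inside the scatter, and on this read-out methyl and chloro cannot be told apart at this position in either core. The two steps can be set side by side: the same change on two cores in this assay, a number 1.5 percentage points higher (within the scatter) from compound 1 to compound 3 and a number 4.4 percentage points higher (within the scatter) from compound 4 to compound 2, 2.9 percentage points apart, within the scatter of two such steps

Going by these compounds, whether an amine, a carboxylic acid or a longer chain at this position would move the read-out beyond the scatter remains open. A reading at one concentration is also not a potency, so any difference in potency among these compounds stays unknown.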